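The source may report more compounds than this note shows. Statements on the series, on what has been measured and on what is new or still open speak of the compounds shown alone.

In an assay on isolated protein for inhibition of Indoleamine 2,3-dioxygenase 2 (Homo sapiens) (on this read-out higher numbers stand for weaker inhibition and lower numbers for stronger inhibition), three compounds built on one shared core have been measured. Compound 1 `OCCc1cn(CCNc2nonc2/C(=N/O)Nc2ccc(F)c(Br)c2)nn1` gives 1170 nM. Compound 2 `CCC(O)c1cn(CCNc2nonc2/C(=N/O)Nc2ccc(F)c(Br)c2)nn1` gives 947 nM, and compound 3 `O/N=C(\Nc1ccc(F)c(Br)c1)c1nonc1NCCn1cc(C2(O)CCCCC2)nn1` gives 865 nM. Compound 2 thus holds the second highest of the three numbers, with compound 3 the nearest and compound 1 the furthest from it, both within the scatter.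

The three measured steps all exchange the group on the same aromatic carbon of the shared core: the step of a 1.2-fold lower number from compound 1 to compound 2 (0.09 log units; within the scatter), the step of a 1.4-fold lower number from compound 1 to compound 3 (0.13 log units; within the scatter) and the step of a 1.1-fold lower number from compound 2 to compound 3 (0.04 log units; within the scatter) each stay within the scatter.

Compound 4 `CC(C)(OCCO)c1cn(CCNc2nonc2/C(=N/O)Nc2ccc(F)c(Br)c2)nn1` is not yet measured. It differs from compound 2 by 1-(2-hydroxyethoxy)-1-methylethyl in place of 1-hydroxypropyl on an aromatic carbon. Because a 1.4-fold lower number from compound 1 to compound 3 (0.13 log units; within the scatter) with its larger ring-bearing group, like a 1.2-fold lower number from compound 1 to compound 2 (0.09 log units; within the scatter) and a 1.1-fold lower number from compound 2 to compound 3 (0.04 log units; within the scatter), has left the number within the scatter, the move to compound 4 is expected to behave the same way, with no step beyond the scatter in this assay in either direction. Compound 4 is therefore estimated to give 950 nM, with a range from 450 nM to 2000 nM. The expected step is a 1.0-fold higher number from compound 2 to compound 4 (0.00 log units; within the scatter), which would be within the scatter.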

Compound 4, half-maximal inhibitory concentration: 1170 nM
Estimate against measurement, compound 4: 1.2-fold (0.09 log units) below, within the range that was stated.
By their numbers in this assay, from the lowest: compounds 3, 2, 1 and 4 (each within the scatter of the next).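

In this assay, the aromatic carbon of the five-membered ring with 3 nitrogen now holds a group with a second oxygen in its chain: 1-(2-hydroxyethoxy)-1-methylethyl, with 7 heavy atoms and 2 hydrogen-bond acceptors, replaces 1-hydroxypropyl, with 4 heavy atoms and 1 hydrogen-bond acceptor, and this gives a 1.2-fold higher number from compound 2 to compound 4 (0.09 log units; within the scatter). For the compounds shown here, the same group in place of 1-hydroxycyclohexyl gives a 1.4-fold higher number from compound 3 to compound 4 (0.13 log units; within the scatter), and in place of 2-hydroxyethyl it gives no change at the digits printed from compound 1 to compound 4 (within the scatter), so all four groups at this position lie within the scatter of one another, and the added chain length and oxygen produce no measurable step here. No supporting data bear on why this position tolerates these exchanges.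

All four groups shown carry a hydroxyl and no net charge, so it remains open whether an amine or a carboxylic acid on this carbon would produce a step beyond the scatter. As far as these compounds go, it is also open whether a longer chain than 1-(2-hydroxyethoxy)-1-methylethyl would do so, and the compounds say nothing about changes elsewhere on the shared core.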